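Furan-to-thiophene swap on a hydrazino cyano-pyrimidinone series

The source may report more compounds than this note shows. Statements on the series, on what has been measured and on what is new or still open speak of the compounds shown alone.

Measured so far:
compound 1 `CSc1nc(-c2cccs2)c(C#N)c(=O)n1C`, 87 ug/mL
compound 2 `Cn1c(NN)nc(-c2ccco2)c(C#N)c1=O`, 65 ug/mL

In a functional assay, with a stated time of 150 min (a lower number here means a stronger inhibitor, a higher number a weaker inhibitor), compound 2 gives 65 ug/mL and compound 1 gives 87 ug/mL. Of the two numbers, compound 2 shows the lowest, but the gap to compound 1 lies within the usual scatter, so the two cannot be ordered. The two compounds also differ in more than one place, so no single step can be read from them.

Compound 3 `Cn1c(NN)nc(-c2cccs2)c(C#N)c1=O` differs from compound 2 in one place: thiophen-2-yl in place of furan-2-yl on an aromatic carbon. In this assay, among the measured compounds shown here, no step between measured compounds is available for this change. Compound 1 already carries thiophen-2-yl and sits within the scatter of compound 2, so the change is expected to give no step beyond the scatter in either direction. Compound 3 is therefore estimated at 70 ug/mL, within 30 ug/mL to 160 ug/mL, an expected step of a 1.1-fold higher number from compound 2 to compound 3 (0.03 log units; within the scatter).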

Compound 3, half-maximal inhibitory concentration: 63 ug/mL
The estimate for compound 3 lay 1.1-fold (0.05 log units) above the measured number; measured number inside the range.
By their numbers in this assay, from the lowest: compounds 3, 2 and 1 (each within the scatter of the next).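

In this assay, among the compounds shown here, thiophen-2-yl in place of furan-2-yl on the aromatic carbon ortho to a cyano group gives a 1.0-fold lower number from compound 2 to compound 3 (0.01 log units; within the scatter) as the first single-place reading at this position, so these two five-membered aromatic rings are not told apart here. Aminoamino in place of methylsulfanyl on an aromatic carbon gives a 1.4-fold lower number from compound 1 to compound 3 (0.14 log units; within the scatter) as a second single-place reading, so that exchange also separates nothing in this assay. No supporting evidence bears on these results.

On these data alone, whether a six-membered ring such as phenyl or pyridyl at the ring-bearing carbon would read differently stays open. Also open, as far as these compounds go, is what a simple amine or a longer chain would give in place of aminoamino, and what a carboxylic acid would give in place of the cyano group.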